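The source may hold more compounds than are shown below. What is called first, only, known or untested is meant among the compounds shown, and "the series" means these compounds.

Measured so far in an ADME assay on WI-38 cells (Homo sapiens) for antiproliferative activity, read by MTT assay, with a stated time of 72 h; on this read-out higher numbers stand for weaker inhibition and lower numbers for stronger inhibition:
- Compound 1, `CCCCCc1ccc(C#Cc2c(-c3ccc(CCCCC)cc3)oc3nc(=O)n(Cc4cn(-c5ccc(Cl)cc5)nn4)cc23)cc1`: its result is a limit of the assay, > 100000 nM.
- Compound 2, `CCCCCc1ccc(C#Cc2c(-c3ccc(CCCCC)cc3)oc3nc(=O)n(Cc4cn(Cc5ccccc5)nn4)cc23)cc1`: 2650 nM.
- Compound 3, `O=c1nc2oc(CCCCl)cc2cn1Cc1cn(Cc2ccccc2)nn1`: 5200 nM.

Compound 1 and compound 2 share a core and differ in one place, (4-chlorophenyl in place of benzyl on an aromatic nitrogen). That change gave an at least 37-fold higher number from compound 2 to compound 1 (1.57 log units; beyond the scatter); the value of compound 1 is a limit, (the limit of > 100000 nM in this assay, at which 1 of the 3 values shown sits), so the step is known only as a lower bound. Compound 3 carries a different core, and the difference between the two cores is not broken down here; its value and that of compound 2 lie within the scatter of each other, so nothing is read into the gap.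

Compound 4, `O=c1nc2oc(CCCCl)cc2cn1Cc1cn(-c2ccc(Cl)cc2)nn1`, is not yet measured. It stands to compound 3 as compound 1 stands to compound 2: 4-chlorophenyl in place of benzyl on an aromatic nitrogen, and the surroundings of the place are the same in both pairs, so it is the same change. On compound 3 one expects a step of about the size seen in an at least 37-fold higher number from compound 2 to compound 1 (1.57 log units; beyond the scatter), that is a 29-fold higher number from compound 3 to compound 4 (1.46 log units; beyond the scatter). Compound 4 is therefore expected to give around 150000 nM in this assay, between 20000 nM and 800000 nM, with a fair chance that only a limit is reported.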

Compound 4, half-maximal inhibitory concentration: 72500 nM
Beside the measured number, compound 4's estimate is 2.1-fold (0.32 log units) above it; the measured number falls inside the stated range.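

In this assay, 4-chlorophenyl in place of benzyl on an aromatic nitrogen again gave a higher number, with a 14-fold higher number from compound 3 to compound 4 (1.14 log units; beyond the scatter), so the direction of the change carried over from the core of compound 2 to the core of compound 3. The size of the step did not carry over unchanged, and the two steps differ: the same change on two cores in this assay, an at least 37-fold higher number (1.57 log units; beyond the scatter) from compound 2 to compound 1 and a 14-fold higher number (1.14 log units; beyond the scatter) from compound 3 to compound 4, at least 2.7-fold (0.43 log units) apart, beyond the scatter of two such steps. Going by these compounds, compound 1 gives only a limit of the assay, so the first step is a lower bound and its true distance from the second stays unknown, and two pairs say nothing about any further core: the limit of > 100000 nM in this assay, at which 1 of the 4 values shown sits.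

The compounds shown leave open whether the step goes with the chlorine or with the change from benzyl to an aryl group; phenyl or 4-chlorobenzyl at that place would separate the two. They also leave open how the step behaves on a core with an amine or a carboxylic acid in place of the chlorine on the chain of compound 3.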